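Swapping methoxy for chloro on a thione-free guess

This account rests on a few compounds, and the source may have more. Where it says the series, first, only, none or still open, it means among the compounds named here.

WRONG_TITLE_PLACEHOLDER

Let me give the final version below.

Trading Methoxy for Chloro

Among the measured compounds shown here, in a functional assay on HepG2 cells (Homo sapiens) for antiproliferative activity, read by sulforhodamine B assay, with a stated time of 48 h (a lower number here means a stronger inhibitor, a higher number a weaker inhibitor), compound 1 `COc1ccc(C2C=C(c3cc(OC)c(OC)c(OC)c3)NC(=S)N2)cc1` gives 90 nM, the higher of the two numbers so far. Compound 2 `COc1cccc(C2=CC(c3ccc(Br)cc3)NC(=S)N2)c1`, which carries bromo, gives 34 nM, lower by more than the scatter. Compound 3 `COc1cc(C2=CC(c3ccc(Cl)cc3)NC(=S)N2)cc(OC)c1OC` has not been measured. It puts chloro in place of methoxy on an aromatic carbon, para to a large group (chloro in place of methoxy on an aromatic carbon). With only compound 2 at 34 nM as a halogen-bearing guide, the step of a 1.8-fold lower number from compound 1 to compound 3 (0.26 log units; within the scatter) is expected to be a small move to a lower number in this assay, probably within the scatter. For compound 3 the estimated value is 50 nM, with an expected range from 15 nM to 170 nM.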

Compound 3, half-maximal inhibitory concentration: 11 nM
The estimate for compound 3 lay 4.5-fold (0.66 log units) above the measured number, and the stated range ends above it.
By their numbers in this assay, from the lowest: compound 3; then compound 2; then compound 1.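

In this assay the change from 4-methoxyphenyl to 4-chlorophenyl gives an 8.2-fold lower number from compound 1 to compound 3 (0.91 log units; beyond the scatter), a drop beyond the usual scatter. Among the compounds shown here, the earlier compounds differed in more than one place, so this is the first direct reading of what this position contributes: on an aromatic carbon, para to a large group, chloro gives a lower number than methoxy. Nothing measured here explains the drop. Going by these compounds, whether other groups here, such as fluoro or an amine, would also lower the number remains open. This single pair cannot show whether the same swap would work on another compound.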